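The source may hold more compounds than are shown below. What is called first, only, known or untested is meant among the compounds shown, and "the series" means these compounds.

Measured in a functional assay; on this read-out higher numbers stand for weaker inhibition and lower numbers for stronger inhibition:
- compound 1 `O=c1oc2ccc(O)cc2cc1-c1ccccc1O`: 24900 nM
- compound 2 `O=c1oc2ccc(O)cc2cc1-c1ccc(O)c(O)c1`: 26800 nM

Only these two compounds have been measured so far. Compound 2 gives 26800 nM and compound 1 gives 24900 nM. Within the data shown here, these values lie within the scatter of each other, so compound 2 stands level with the only other measured compound. The two also differ in more than one place, so neither value shows what a single change on the shared core does.

Compound 3 `O=c1oc2cc(O)c(O)cc2cc1-c1ccc(O)c(O)c1` is still to be measured in this assay. It departs from compound 2 in one place: hydroxy in place of hydrogen on an aromatic carbon. This is hydroxy in place of hydrogen on an aromatic carbon, ortho to a hydroxy group.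

Among the measured compounds shown here, the series holds no measured step for this change, so any expectation is loose. A moderate move to a lower number, beyond the scatter, is expected, and a result level with compound 2 would not be surprising. The expected change is a 3.8-fold lower number from compound 2 to compound 3 (0.58 log units; beyond the scatter). Compound 3 is estimated at 7000 nM, with an expected range of 1500 nM to 30000 nM.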

Compound 3, half-maximal inhibitory concentration: 9800 nM
Compound 3: middle estimate off by 1.4-fold (0.15 log units), on the low side, and the stated range covers the measured number.
By their numbers in this assay, from the lowest: compound 3; then compounds 1 and 2 (each within the scatter of the next).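

In this assay the series now has its first step at a single place: a 2.7-fold lower number from compound 2 to compound 3 (0.44 log units; beyond the scatter), on hydroxy replacing hydrogen on an aromatic carbon, ortho to a hydroxy group. This shows that the position responds to substitution, with the added hydroxy moving the read-out modestly towards stronger inhibition, something the comparison of compound 1 with compound 2 could not show because those two differ in more than one place. No measurement available here accounts for the step, so its origin remains unassigned.

This single step cannot show whether the shift is specific to hydroxy or would also appear with methoxy, fluorine or an amine on the same aromatic carbon. It also leaves open whether hydroxy would give a similar step on a compound lacking the neighbouring ortho hydroxy group, or on the core of compound 1, which carries a different pattern of hydroxy groups on its pendant ring.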